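The compounds below may be only part of what the source reports. "The series", "measured", "known", "first", "only" and "open" are said of these compounds alone.

Measured so far:
- compound 1, `Nc1ncnc2c1c(Oc1cc(C(F)(F)F)ccn1)nn2C1CC1`: > 2.41 h
- compound 2, `N#Cc1ccnc(Oc2nn(C3CC3)c3ncnc(N)c23)c1`: > 2.41 h
- compound 3, `Nc1ncnc2c1c(Oc1cc(Cl)ccn1)nn2[C@H]1C[C@H](F)C1`: 0.127 h

In an ADME assay on microsomes from liver (Mus musculus) for metabolic stability, read by LC-MS, using NADPH, with a stated time of 10 min, tested at 10 uM (on this read-out lower numbers stand for a shorter-lived compound and higher numbers for a longer-lived compound), compound 1 gives only a limit, > 2.41 h, not a number. Compound 2 likewise sits at a limit, > 2.41 h. Both rest at the limit of > 2.41 h in this assay, at which 2 of the 3 values shown sit, so the step that the two limits leave unreadable from compound 1 to compound 2 cannot be read in size. For the measured compounds named here, compound 3 differs from compound 1 in two places, and no single step links it to compound 1. In this assay compound 3 gives a number, 0.127 h.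

Compound 4, `Nc1ncnc2c1c(Oc1cc(C(F)(F)F)ccn1)nn2C1CCC1`, is not yet measured. It differs from compound 1 by cyclobutyl in place of cyclopropyl on an aromatic nitrogen. Going by the values given here, none of the measured steps touches the group on the aromatic nitrogen, so no measured step bears on this change, and the only read of compound 1 is a limit. The expectation is therefore a step of an at least 1.3-fold lower number from compound 1 to compound 4 (0.12 log units; that floor lies within the scatter) of no readable size beyond the scatter, with compound 4 estimated near the limit at 1.8 h, range 0.5 h to 4 h.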

Compound 4, half-life: 0.128 h
Estimate against measurement, compound 4: 14-fold (1.15 log units) above; the whole stated range lies above it.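

In this assay, the group on the aromatic nitrogen proves to be a sensitive position: an at least 18-fold lower number from compound 1 to compound 4 (1.27 log units; beyond the scatter). For the compounds shown here, compound 1 gives only a limit, so that step is a floor and its full size stays open: the limit of > 2.41 h in this assay, at which 2 of the 4 values shown sit. The one earlier step between single-change neighbours, at the aromatic carbon, cannot be read, which makes this the first readable single change, with the trifluoromethyl group and the rest of the structure shared by both compounds.

The compounds shown leave open whether the step follows ring size or is particular to cyclobutyl, a question that an ethyl, isopropyl or oxetanyl group on the same nitrogen would address. They also leave open whether a nitrile in place of trifluoromethyl changes the read-out when cyclobutyl sits on that nitrogen.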